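The source may hold more compounds than are shown below. What is called first, only, known or untested is meant among the compounds shown, and "the series" means these compounds.

Compound 1 `O=C(NCc1ccc(F)cc1)c1cccnc1Oc1ccc(F)cc1` is measured in a functional assay on the whole organism with Mus musculus as the target (a higher number here means that more compound is needed for the effect, a lower number that less compound is needed), at 0.01 mg/kg. Compound 2 `O=C(NCc1ccccc1)c1cccnc1Oc1ccccc1F` gives 0.01 mg/kg in this assay, and compound 3 `COc1ccc(Oc2ncccc2C(=O)NCc2ccccc2)cc1` gives 0.01 mg/kg, so compound 1 stands level with both within the scatter. For the measured compounds named here, the only step between measured compounds, no change at the digits printed from compound 2 to compound 3 (within the scatter), concerns the group on the oxygen and leaves the amide nitrogen untouched. Compound 4 `O=C(Nc1ccccc1)c1cccnc1Oc1ccc(F)cc1` differs from compound 1 in phenyl in place of 4-fluorobenzyl on an amide-type nitrogen. Going by the values given here, no measured step bears on a change at the amide nitrogen, so the measured compounds offer no direct guide, and the expectation rests on the narrow spread of the three values. Compound 4 is expected to fall at 0.03 mg/kg, between 0.005 mg/kg and 0.3 mg/kg. The step of a 3.0-fold higher number from compound 1 to compound 4 (0.48 log units; beyond the scatter) is estimated to be modest, with wide uncertainty.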

Compound 4, minimum effective dose: 0.001 mg/kg
Compound 4: middle estimate off by 30-fold (1.48 log units), on the high side; the measured number lies below the stated range.
By their numbers in this assay, from the lowest: compound 4; then compounds 1, 2 and 3 (each within the scatter of the next).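

For the compounds shown here, with a 10-fold lower number from compound 1 to compound 4 (1.00 log units; beyond the scatter) in this assay the amide nitrogen emerges as a place that responds, unlike the group on the oxygen in the one earlier step. Phenyl on this nitrogen needs less compound than 4-fluorobenzyl, so the benzyl carbon and the fluorine are not required for the effect in this pair. Nothing given here explains the result.

Going by these compounds alone, the single swap changes both features at once, leaving their separate contributions open. As far as these compounds go, how 4-fluorophenyl, 2-phenylethyl or a cyclohexyl ring would fare on this nitrogen also remains open.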